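Swapping fluoro for methyl on the aromatic ring

A few compounds are considered here, and "the series" means these few. Any claim that something is new, unique, unknown or untested is made for them only; others in the source may bear on it.

Among the measured compounds shown here, compound 1 `NC(=O)CCc1cnc(N2CCC(c3nc(COc4ccc(-n5cnnn5)cc4)cs3)CC2)nc1` shares the core with compound 2 `CCc1cnc(N2CCC(c3nc(COc4ccc(/C=C5\CC(=O)NC5=O)cc4F)cs3)CC2)nc1`, but in a functional assay on cells for agonist activity at Glucose-dependent insulinotropic receptor (Homo sapiens), read by a luciferase reporter, with a stated time of 6 h (on this read-out higher numbers stand for an effect only at larger amounts of compound and lower numbers for an effect already at smaller amounts), compound 1 gives "not determined" (no result reported), so compound 2 holds the only number here. In this assay compound 2 gives 49 nM. Compound 3 `CCc1cnc(N2CCC(c3nc(COc4ccc(/C=C5\CC(=O)NC5=O)cc4C)cs3)CC2)nc1` differs from compound 2 in one place: methyl in place of fluoro on an aromatic carbon. For the measured compounds named here, no measured pair shows what such a swap does, so the expected step of a 1.2-fold higher number from compound 2 to compound 3 (0.09 log units; within the scatter) is small and of uncertain direction, within the usual scatter. Compound 3 is therefore estimated at 60 nM, in a range from 20 nM to 180 nM.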

Compound 3, half-maximal effective concentration: 18 nM
The estimate for compound 3 lay 3.3-fold (0.52 log units) above the measured number; measured number outside the range, below it.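

This position on the aromatic ring, ortho to a large group, responds to a one-atom swap: in this assay methyl in place of fluoro gives a 2.7-fold lower number from compound 2 to compound 3 (0.43 log units; beyond the scatter) and this modest step lies beyond the usual scatter. Both groups count one heavy atom and neither has a hydrogen-bond donor or acceptor, so these counts do not separate them. Nothing at hand explains the step. The compounds shown leave open how chloro, ethyl or methoxy at this position would read, and whether the same swap gives a similar step elsewhere on the aromatic ring.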